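The compounds below may be only part of what the source reports. "The series", "measured", "known", "first", "only" and "open" are said of these compounds alone.

Values in an ADME assay on a cell-free system (plasma, Homo sapiens) for metabolic stability, read by HPLC (on this read-out lower numbers stand for a shorter-lived compound and higher numbers for a longer-lived compound), each one a limit and not a number:
compound 1 `CCCC(CCC)C(=O)N(C)/N=N/c1ccc(C(=O)OCC)cc1`: > 40 h
compound 2 `CCCC(CCC)C(=O)N(C)/N=N/c1ccc(C(=O)OC)cc1`: > 40 h
compound 3 `CCCC(CCC)C(=O)N(C)/N=N/c1ccc(Cl)cc1`: > 40 h

Among the compounds with values here, the series so far shows (the limit of > 40 h in this assay, at which 3 of the 3 values shown sit). Compound 3 therefore has no exact place in the series, and its > 40 h is only a limit.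

Compound 4 `CCCC(CCC)C(=O)N(C)/N=N/c1ccc(C)cc1` carries methyl in place of chloro on an aromatic carbon. The change lies on an aromatic carbon of a six-membered aromatic ring of carbon only, para to a large group.

Two measured steps replace a group in that same place: a step that the two limits leave unreadable from compound 1 to compound 3 and a step that the two limits leave unreadable from compound 2 to compound 3. A third, a step that the two limits leave unreadable from compound 1 to compound 2, changes the series elsewhere. None of the three has a readable size, so they give no measured size or direction to carry over to the new change. In this assay no step beyond the scatter is therefore expected, and a report of compound 4 at the same limit is the likeliest outcome. The expected change is a step that the limit leaves unreadable from compound 3 to compound 4, and this estimate has no direction grounded in the measurements. For compound 4 the estimated half-life is 50 h, with an expected range of 25 h to 100 h.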

Compound 4, half-life in the Homo sapiens assay: > 40 h
Compound 4: a limit, no number; the forecaster's own chance of this, stated with the estimate: 75%; the middle value does not contradict the limit.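

In the Homo sapiens assay compound 4 gives > 40 h. This value is a limit and not a number. Within the data shown here, no step from compound 1, compound 2 or compound 3 to compound 4 can be read, since all four compounds share one limit: the limit of > 40 h in the Homo sapiens assay, at which 4 of the 4 values shown sit.

In a physicochemical assay for pharmacokinetics, read by HPLC, in phosphate buffer, at pH 7.4 (on this read-out lower numbers stand for a shorter-lived compound and higher numbers for a longer-lived compound), compound 3 gives 27.3 h and compound 4 gives 31.3 h. In the physicochemical assay this is a 1.1-fold higher number from compound 3 to compound 4 (0.06 log units; within the scatter).

The compounds shown leave open whether changing the group on the aromatic carbon alters the half-life in the Homo sapiens assay at all.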